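The source may report more compounds than this note shows. Statements on the series, on what has been measured and on what is new or still open speak of the compounds shown alone.

Working notes on the series. Compound 1 `CCNC(=O)[C@H]1O[C@@H](n2cnc3c(NNC(=O)c4ccc(Br)o4)ncnc32)[C@H](O)[C@@H]1O` in an assay on CHO cells for displacement of a labelled ligand from adenosine receptor A1 (Homo sapiens) (on this read-out lower numbers stand for stronger inhibition and higher numbers for weaker inhibition), gives 780 nM. Compound 2 `CCNC(=O)[C@H]1O[C@@H](n2cnc3c(NNC(=O)c4ccccc4)nc(Cl)nc32)[C@H](O)[C@@H]1O` returns only a limit of this assay, > 5000 nM, not a number, as recorded in the limit of > 5000 nM in this assay, at which 1 of the 2 values shown sits. Compound 3 `CCNC(=O)[C@H]1O[C@@H](n2cnc3c(NNC(=O)c4cc(-c5ccccc5)on4)nc(Cl)nc32)[C@H](O)[C@@H]1O` carries 5-phenyl-1,2-oxazol-3-yl in place of phenyl on a carbonyl carbon. For the measured compounds named here, no step between measured compounds is at hand, so the size of the change in this assay cannot be read from the series itself. Compound 3 is expected to remain weak, estimated at 7000 nM, within 2500 nM to 20000 nM. The expected step, a step that the limit leaves unreadable from compound 2 to compound 3, is small and may not exceed the usual scatter.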

Compound 3, inhibition constant: > 5000 nM
Compound 3: a limit, no number (the forecaster's own chance of this, stated with the estimate: 60%); the middle value lies beyond the limit too.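

No step can be read between compound 2 and compound 3, because both give only a limit: the limit of > 5000 nM in this assay, at which 2 of the 3 values shown sit.

The compounds shown leave open what change, if any, 5-phenyl-1,2-oxazol-3-yl in place of phenyl on a carbonyl carbon brings in this assay.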